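Swapping Phenyl for Furan-2-yl on the Shared Core

The compounds below may be only part of what the source reports. "The series", "measured", "known", "first", "only" and "open" are said of these compounds alone.

Of the compounds shown here, three have been tested in a functional assay on DU-145 cells (Homo sapiens) for cytotoxicity, read by CCK-8 assay and cell counting, with a stated time of 2 days; a higher number here means a weaker inhibitor, a lower number a stronger inhibitor. Compound 3 `Oc1cccc(-c2cc(-c3ccccc3)nc(-c3ccccc3Cl)c2)c1` gives 1480 nM. Compound 1 `Oc1ccc(-c2cc(-c3ccco3)nc(-c3ccccc3Cl)c2)cc1` gives 5300 nM in this assay. For compound 2 `Oc1cccc(-c2cc(-c3cccnc3)nc(-c3ccccc3Cl)c2)c1` the result in this assay is "not determined" (no result reported), so no number is reported for it. Of the two numbers, compound 3 stands lowest, and compound 1 is the nearest, differing from compound 3 in two places and sitting beyond the scatter. Compound 4 `Oc1cccc(-c2cc(-c3ccco3)nc(-c3ccccc3Cl)c2)c1` has not yet been measured. It differs from compound 3 in one place: furan-2-yl in place of phenyl on an aromatic carbon. Going by the values given here, no step between measured compounds that differ in only this one place is available to calibrate the exchange. A mild move toward a higher number is expected because compound 1 gives 5300 nM, a weaker result than compound 3, even though compound 1 also carries a furan-2-yl group and differs from compound 3 in a second place as well. The expected step from compound 3 to compound 4 is a 1.7-fold higher number from compound 3 to compound 4 (0.23 log units; within the scatter), which may well stay within the scatter. Compound 4 is estimated at 2500 nM, with a range from 900 nM to 7000 nM.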

Compound 4, half-maximal inhibitory concentration: 1630 nM
For compound 4 the middle estimate is 1.5-fold (0.19 log units) above the measured one, within the range that was stated.
By their numbers in this assay, from the lowest: compounds 3 and 4 (each within the scatter of the next); then compound 1.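

In this assay, furan-2-yl and phenyl can be exchanged at this position, next to the ring nitrogen, with no difference beyond the scatter: a 1.1-fold higher number from compound 3 to compound 4 (0.04 log units; within the scatter). With furan-2-yl held in place, the exchange of 4-hydroxyphenyl for 3-hydroxyphenyl gives a step beyond the scatter, so the hydroxyphenyl group is the place where a real difference shows: a 3.3-fold lower number from compound 1 to compound 4 (0.51 log units; beyond the scatter). No outside measurement bears on why either result comes out as it does.

On these data alone, it remains open whether the position tolerates groups of a different kind, such as an amine, a carboxylic acid or a longer alkyl chain, as well as it tolerates these two rings. As far as these compounds go, it also remains open whether the difference between 3-hydroxyphenyl and 4-hydroxyphenyl holds when phenyl replaces furan-2-yl.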